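The source may hold more compounds than are shown below. What is called first, only, known or untested is meant among the compounds shown, and "the series" means these compounds.

Compound 2, with structure `CC(C)[C@H](NC(=O)COc1cccc2ccccc12)C(=O)N[C@@H](CC(=O)O)C(=O)COc1cc(F)c(F)cc1F`, is the higher of the two numbers gathered so far in a functional assay with Homo sapiens as the target (on this read-out higher numbers stand for weaker inhibition and lower numbers for stronger inhibition), where compound 2 gives 16700 nM. Its nearest neighbour is compound 1, with structure `CC(C)[C@H](NC(=O)COc1cccc2ccccc12)C(=O)N[C@@H](CC(=O)O)C(=O)COc1ccc(F)c(F)c1`, and in this assay compound 1 gives 16200 nM. Among the measured compounds shown here, the only step between measured compounds runs from compound 1 to compound 2, and that step, a 1.0-fold higher number from compound 1 to compound 2 (0.01 log units; within the scatter), did not move the number beyond the scatter of repeated measurements.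

Compound 3, with structure `CC(C)[C@H](NC(=O)COc1cccc2ccccc12)C(=O)N[C@@H](CC(=O)O)C(=O)COc1ccc([N+](=O)[O-])cc1F`, is the next compound to be measured. The change from compound 2 to compound 3 is 2-fluoro-4-nitrophenyl in place of 2,4,5-trifluorophenyl on an oxygen on a saturated carbon. For the measured compounds named here, no measured step involves a nitro group or the removal of two fluorine atoms, so the single step on record bears only loosely on this change: it shows that one alteration on this ring left this assay unchanged. On that thin basis a step of a 1.0-fold lower number from compound 2 to compound 3 (0.02 log units; within the scatter) is expected, with no shift beyond the scatter. Compound 3 is therefore estimated to give 16000 nM in this assay, within a range from 5000 nM to 50000 nM.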

Compound 3, half-maximal inhibitory concentration: 15800 nM
The estimate for compound 3 lay 1.0-fold (0.01 log units) above the measured number; the range from low to high includes it.
By their numbers in this assay, from the lowest: compounds 3, 1 and 2 (each within the scatter of the next).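

Replacing the 2,4,5-trifluorophenyl group with 2-fluoro-4-nitrophenyl, on an oxygen on a saturated carbon, gives in this assay a 1.1-fold lower number from compound 2 to compound 3 (0.02 log units; within the scatter). The earlier step changed only the fluorine count on this ring, whereas this one brings in a nitro group and, with it, two hydrogen-bond acceptors that neither fluorinated ring in compound 1 or compound 2 counts, and the number still does not move beyond the scatter. The comparison with the 3,4-difluorophenyl group gives the same picture, with a 1.0-fold lower number from compound 1 to compound 3 (0.01 log units; within the scatter), so this assay does not separate these three rings, and no measurement at hand offers an explanation for that.

From the compounds shown here alone, all three compounds keep a fluorine-bearing phenyl group on that oxygen and share the same core, so it remains open whether changes to that core would shift the number. Also open, going by these compounds, is what a plain phenyl ring, an amine or carboxylic acid on the ring, or a saturated alkyl chain in place of the ring would do in this assay.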